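Compound 1 and a shorter side chain

This account rests on a few compounds, and the source may have more. Where it says the series, first, only, none or still open, it means among the compounds named here.

- compound 1 (`COC(=O)/C=C\[C@H]1OCCC[C@H]1O[Si](C)(C)C(C)(C)C`) gives 6300 nM
- compound 2 (`COC(=O)/C=C/[C@H]1OCCC[C@H]1O`) gives > 100000 nM as a limit
- compound 3 (`O=C1C=C[C@H]2OCCC[C@H]2O1`) gives 5700 nM

In a functional assay on SW1573 cells (Homo sapiens) for antiproliferative activity, read by sulforhodamine B assay, with a stated time of 48 h (on this read-out higher numbers stand for weaker inhibition of growth and lower numbers for stronger inhibition of growth), compound 1 stands at 6300 nM and compound 3 at 5700 nM within the scatter of each other. Compound 2 gave a limit and not a number. Compound 4 (`C=C[C@H]1OCCC[C@H]1O[Si](C)(C)C(C)(C)C`) is still unmeasured. It carries vinyl in place of 2-(methoxycarbonyl)ethenyl on a saturated ring carbon. Within the data shown here, no measured pair shows this change alone. Weaker inhibition of growth, beyond the scatter, is expected in this assay as the estimated step (a 4.0-fold higher number from compound 1 to compound 4 (0.60 log units; beyond the scatter)) towards a higher number. Compound 4 is estimated at 25000 nM with an expected range of 7000 nM to 90000 nM in this measurement.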

Compound 4, concentration for 50% growth inhibition: > 100000 nM
Compound 4 ended at the assay's limit; the forecaster's own chance of this, stated with the estimate: 30%; middle value at least 4.0-fold (0.60 log units) from the limit.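

Vinyl in place of 2-(methoxycarbonyl)ethenyl on this saturated ring carbon, with the rest of compound 1 unchanged, gives an at least 15-fold higher number from compound 1 to compound 4 (1.20 log units; beyond the scatter). Among these compounds, this is the first single-place change read at this position, and it shows that growth inhibition depends on the group lost here. Compound 4 gives a limit and not a number, so the true size of the step is unknown: the limit of > 100000 nM in this assay, at which 2 of the 4 values shown sit.

The compounds shown leave open whether the methoxycarbonyl end or the length of the chain matters, and how a carboxylic acid or an amide there would read.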